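Replacing 3,4-dichlorophenyl with 4-acetylphenyl in compound 3

The compounds below may be only part of what the source reports. "The series", "measured", "known", "first", "only" and "open" are said of these compounds alone.

Measured so far in a functional assay on HeLa cells (Homo sapiens) for antiproliferative activity, read by MTT assay, with a stated time of 72 h; on this read-out lower numbers stand for stronger inhibition and higher numbers for weaker inhibition:
Compound 1 `Nc1nc(N)c2cc(CSC(=S)N3CCN(C4CCCCC4)CC3)ccc2n1` gives 5960 nM
Compound 2 `Cc1ccc(N2CCN(C(=S)SCc3ccc4nc(N)nc(N)c4c3)CC2)c(C)c1` gives 3190 nM
Compound 3 `Nc1nc(N)c2cc(CSC(=S)N3CCN(c4ccc(Cl)c(Cl)c4)CC3)ccc2n1` gives 3060 nM

Compound 3, at 3060 nM, stands within the scatter of both other compounds, so this assay does not separate it from either. Compound 4 `CC(=O)c1ccc(N2CCN(C(=S)SCc3ccc4nc(N)nc(N)c4c3)CC2)cc1` has not yet been measured. It differs from compound 3 in one place, on an amine nitrogen in a ring, with 4-acetylphenyl in place of 3,4-dichlorophenyl on an amine nitrogen in a ring.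

Among the measured compounds shown here, three measured steps bear on this change, all made at that same nitrogen. Exchanging cyclohexyl for a substituted phenyl gave a 1.9-fold lower number from compound 1 to compound 2 (0.27 log units; within the scatter) and a 1.9-fold lower number from compound 1 to compound 3 (0.29 log units; within the scatter). For the measured compounds named here, the closest precedent, one substituted phenyl for another, gave a 1.0-fold lower number from compound 2 to compound 3 (0.02 log units; within the scatter). Going by the values given here, none of the measured compounds carries an acetyl group, so the data cannot show what that group does. On the strength of these three small steps, no step beyond the scatter is expected in this assay, and neither direction is favoured. The estimate amounts to a 1.1-fold higher number from compound 3 to compound 4 (0.06 log units; within the scatter) as the expected step. Compound 4 is expected at about 3500 nM, with an estimated range from 1500 nM to 8000 nM.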

Compound 4, half-maximal inhibitory concentration: 2040 nM
Compound 4: middle estimate off by 1.7-fold (0.23 log units), on the high side, and the stated range covers the measured number.
By their numbers in this assay, from the lowest: compounds 4, 3, 2 and 1 (each within the scatter of the next, the first and the last beyond it).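

In this assay, 4-acetylphenyl is the only group at this amine nitrogen that carries a hydrogen-bond acceptor, and it leaves the number within the scatter of both other substituted phenyl compounds, with a 1.5-fold lower number from compound 3 to compound 4 (0.18 log units; within the scatter) and a 1.6-fold lower number from compound 2 to compound 4 (0.19 log units; within the scatter), so exchanges among these substituted phenyl groups remain unresolved in this assay. Among the compounds shown here, the new information lies in the comparison with the cyclohexyl compound: a 2.9-fold lower number from compound 1 to compound 4 (0.47 log units; beyond the scatter) is the only modest step beyond the scatter, whereas compound 2 and compound 3 each remain within the scatter of compound 1, so this separation rests on a single pair and does not extend to substituted phenyl groups in general. Nothing measured on these compounds accounts for this difference.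

Whether the acetyl group itself matters remains open, since the compounds shown do not include an unsubstituted phenyl or a phenyl carrying an amine or a carboxylic acid in its place. It is also unknown whether a longer chain on the carbonyl would keep the number in the same range.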